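This account rests on a few compounds, and the source may have more. Where it says the series, first, only, none or still open, it means among the compounds named here.

Compound 1 `COc1ccccc1Nc1nc(SCc2ccc(C(F)(F)F)cc2)nc2ccccc12` and compound 2 `Fc1ccc(Nc2nc(SCc3ccc(C(F)(F)F)cc3)nc3ccccc23)cc1` share one core and differ only in the group on the ring nitrogen. In a functional assay on MGC-803 cells (Homo sapiens) for cytotoxicity, read by MTT assay, with a stated time of 72 h (a higher number here means a weaker inhibitor, a lower number a stronger inhibitor), compound 1 gives only a limit, > 50000 nM, and this is the limit of > 50000 nM in this assay, at which 1 of the 2 values shown sits. In this assay, for the measured compounds named here, compound 2 gives 9620 nM, the only full number in the set, so compound 2 stands alone as the reference point. Going by the values given here, the single measured step, an at least 5.1-fold lower number from compound 1 to compound 2 (0.71 log units; beyond the scatter), is the only guide available. Compound 3 `FC(F)(F)c1ccc(CSc2nc(Nc3ccc(C(F)(F)F)cc3)c3ccccc3n2)cc1` is drawn from compound 2 by a change (trifluoromethyl in place of fluoro on an aromatic carbon). Among the compounds with values here, no measured step compares fluoro with trifluoromethyl on this ring; the step from compound 1 to compound 2 reworked the same ring but swapped a different group at a different place. Compound 3 is therefore expected to move little, with an estimated step of a 1.2-fold lower number from compound 2 to compound 3 (0.08 log units; within the scatter). Compound 3 is expected to give about 8000 nM in this assay, within 3000 nM to 25000 nM.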

Compound 3, half-maximal inhibitory concentration: 6170 nM
Beside the measured number, compound 3's estimate is 1.3-fold (0.11 log units) above it, and the stated range covers the measured number.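

In this assay, the step at this aromatic carbon, para to a large group, is a 1.6-fold lower number from compound 2 to compound 3 (0.19 log units; within the scatter), so going from fluoro to trifluoromethyl, one heavy atom to four, gives no difference that can be read. Against the 2-methoxyphenyl group of compound 1, 4-(trifluoromethyl)phenyl gives an at least 8.1-fold lower number from compound 1 to compound 3 (0.90 log units; beyond the scatter), so a second 4-substituted phenyl now reads as a full number, as 4-fluorophenyl did. Compound 1 stands at a limit, so this step is a bound and not a size: the limit of > 50000 nM in this assay, at which 1 of the 3 values shown sits.

The compounds shown leave open whether another group at this place, such as an amine or a carboxylic acid, would separate from fluoro and trifluoromethyl. They also leave open whether a methoxy group at the same place would behave like these two groups or like the 2-methoxyphenyl of compound 1.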